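The compounds below may be only part of what the source reports. "The series", "measured", "known", "first", "only" and "open" are said of these compounds alone.

Of the compounds shown here, three have been measured in a functional assay on the whole organism (strain Wistar) for inhibition, with Rattus norvegicus as the target, read by paw edema, with stated times of 1 h and 3 h, at a dose of 200 mg/kg by the oral route; on this read-out higher numbers stand for more inhibition at the one dose given (going by the name of the read-out) and lower numbers for less inhibition. Compound 1 `Cc1ccc(NCC2CCC/C(=C\c3ccccc3)C2=O)cc1` gives 72.3%. For the measured compounds named here, compound 2 `Cc1ccc(N(C)CC2CCC/C(=C\c3ccccc3)C2=O)cc1` gives 25.5%, and the one change between them, methyl in place of hydrogen on a nitrogen on an aromatic ring, brings a number 46.8 percentage points lower from compound 1 to compound 2 (beyond the scatter). Compound 3 `Cc1cccc(N(C)CC2CCC/C(=C\c3ccccc3)C2=O)c1` gives 46.8%; here 3-methylphenyl replaces 4-methylphenyl on the amine nitrogen, and this gives a number 21.3 percentage points higher from compound 2 to compound 3 (beyond the scatter). Compound 3 therefore stands second highest of the three numbers, above compound 2 and below compound 1, both gaps beyond the scatter.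

Compound 4 `Cc1ccc(/C=C2\CCCC(CN(C)c3cccc(C)c3)C2=O)cc1` differs from compound 3 in a different part of the molecule: methyl in place of hydrogen on an aromatic carbon. Neither measured step touches this position; both concern the amine nitrogen and the ring attached to it. Going by the values given here, there is thus no direct precedent for adding a methyl to this ring. Compound 1 and compound 2 show how sensitive this assay can be to a single methyl, yet that was on a nitrogen, not on an aromatic carbon. Among the compounds with values here, with no step bearing directly on this change, the expectation is a step no larger than the scatter, so compound 4 is estimated to stay close to compound 3, giving a number 1.2 percentage points higher from compound 3 to compound 4 (within the scatter). Compound 4 is expected to show about 48%, within the range 30% to 65%.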

Compound 4, a percentage reported as inhibition, in the whole organism at one dose (the size of the read-out at that dose, not a potency): 36.2%
The estimate for compound 4 lay 11.8 percentage points above the measured number; the measured number falls inside the stated range.
By their numbers in this assay, from the lowest: compound 2; then compound 4; then compound 3; then compound 1.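

In this assay, for the compounds shown here, the earlier steps touched only the amine nitrogen and the ring attached to it, whereas the change from phenyl to 4-methylphenyl shows that the other aromatic ring matters too, with a number 10.6 percentage points lower from compound 3 to compound 4 (beyond the scatter) for the addition of a single carbon. Sensitivity to one methyl is therefore not limited to the amine nitrogen, since a methyl on an aromatic carbon, para to a large group, also moves the number beyond the scatter, although this modest step is smaller than the large one seen at the nitrogen, a number 46.8 percentage points lower from compound 1 to compound 2 (beyond the scatter). Nothing measured here explains why the number falls at this position.

The compounds shown leave open whether the fall is particular to methyl or would also follow from a chlorine, a methoxy group or a hydroxyl group in the same place. They also leave open whether the same methyl would lower the number in compound 1, which keeps the hydrogen on its nitrogen and has the highest number of the series.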